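A Methyl-to-Hydrogen Swap Repeated on a Chloro Analogue

This account rests on a few compounds, and the source may have more. Where it says the series, first, only, none or still open, it means among the compounds named here.

Four closely related compounds are compared in a functional assay on thoracic aorta (Rattus norvegicus, strain Wistar), with a stated time of 15 min; on this read-out higher numbers stand for an effect only at larger amounts of compound and lower numbers for an effect already at smaller amounts. Compound 1 `CC(C)Oc1ccc(Br)cc1C(C)NC(=O)N(C)S(=O)(=O)c1ccccc1` gives 32100 nM. Compound 2 `CC(C)Oc1ccc(Br)cc1C(C)NC(=O)NS(=O)(=O)c1ccccc1` differs from compound 1 by hydrogen in place of methyl on an amide-type nitrogen. In this assay compound 2 gives 143000 nM; the step is a 4.5-fold higher number from compound 1 to compound 2 (0.65 log units; beyond the scatter). Compound 3 `CC(C)Oc1ccc(Br)cc1C(C)NC(=O)N(C)S(=O)(=O)c1ccc(Cl)cc1` differs from compound 1 by chloro in place of hydrogen on an aromatic carbon. In this assay compound 3 gives 43200 nM, and the step is a 1.3-fold higher number from compound 1 to compound 3 (0.13 log units; within the scatter). Compound 4 `CC(C)Oc1ccc(Br)cc1C(C)NC(=O)NS(=O)(=O)c1ccc(Cl)cc1` has not yet been measured; it differs from compound 3 by hydrogen in place of methyl on an amide-type nitrogen, which is the same change, at the same place, that turned compound 1 into compound 2. From compound 3 to compound 4 the expected step is a 4.2-fold higher number from compound 3 to compound 4 (0.62 log units; beyond the scatter). That expectation rests on the same change having made a 4.5-fold higher number from compound 1 to compound 2 (0.65 log units; beyond the scatter). Compound 4 is therefore expected to give 180000 nM, with a likely range from 85000 nM to 400000 nM.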

Compound 4, half-maximal effective concentration: 122000 nM
The estimate for compound 4 lay 1.5-fold (0.17 log units) above the measured number; the measured number falls inside the stated range.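

Taking the methyl off the amide-type nitrogen on the chloro core gave a 2.8-fold higher number from compound 3 to compound 4 (0.45 log units; beyond the scatter) in this assay, and this step agrees with the earlier one on the core of compound 1: the same change on two cores in this assay, a 4.5-fold higher number (0.65 log units; beyond the scatter) from compound 1 to compound 2 and a 2.8-fold higher number (0.45 log units; beyond the scatter) from compound 3 to compound 4, 1.6-fold (0.20 log units) apart, within the scatter of two such steps. Adding the chloro group to the compound without that methyl gave a 1.2-fold lower number from compound 2 to compound 4 (0.07 log units; within the scatter), and this also matches its earlier counterpart: the same change on two cores in this assay, a 1.3-fold higher number (0.13 log units; within the scatter) from compound 1 to compound 3 and a 1.2-fold lower number (0.07 log units; within the scatter) from compound 2 to compound 4, 1.6-fold (0.20 log units) apart, within the scatter of two such steps. So the methyl change carried over between these two cores, which differ only by a chloro group, but this does not show that it would carry over to a core that differs more, nor why the number moves.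

The compounds shown leave open whether a longer chain such as ethyl on that nitrogen would act like methyl. They also leave open whether a methoxy group in place of the chloro would leave the number as unchanged.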